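This account rests on a few compounds, and the source may have more. Where it says the series, first, only, none or still open, it means among the compounds named here.

Of the compounds shown here, two with a shared core have been measured. Compound 1 `CC1(C)CC(NC(=O)c2ccc(Nc3ncc([N+](=O)[O-])c(N4CCN(c5ccc(F)cc5)CC4)n3)cc2)CC(C)(C)N1[O]` and compound 2 `Cc1cc(Nc2nc(Nc3ccc(C(=O)NC4CC(C)(C)N([O])C(C)(C)C4)cc3)ncc2[N+](=O)[O-])no1` were tested in a functional assay on HeLa cells (Homo sapiens) for antiproliferative activity, read by MTT assay, with a stated time of 48 h; a higher number here means a weaker inhibitor, a lower number a stronger inhibitor. There compound 1 gives 25300 nM, while compound 2 gives 7360 nM, the lower of the two numbers, and the gap between them lies beyond the scatter of repeated measurements. Compound 3 `CCOC(=O)Cc1csc(Nc2nc(Nc3ccc(C(=O)NC4CC(C)(C)N([O])C(C)(C)C4)cc3)ncc2[N+](=O)[O-])n1` is the next compound, not yet measured. It differs from compound 2 in one place: 4-((ethoxycarbonyl)methyl)-1,3-thiazol-2-yl in place of 5-methyl-1,2-oxazol-3-yl on a nitrogen on an aromatic ring. Going by the values given here, no step between measured compounds shows the effect of this change, so the expectation rests on the two numbers alone. Among the compounds with values here, the entering group is larger than the one it replaces, and the only other measured change of this kind, compound 1 against compound 2, went toward a weaker inhibitor. The step from compound 2 to compound 3 is expected to be a 1.6-fold higher number from compound 2 to compound 3 (0.21 log units; within the scatter). For compound 3 the expected value in this assay is 12000 nM, within a range from 3000 nM to 45000 nM.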

Compound 3, half-maximal inhibitory concentration: 12000 nM
The estimate for compound 3 equals the measured number at the digits printed; measured number inside the range.
By their numbers in this assay, from the lowest: compounds 2 and 3 (each within the scatter of the next); then compound 1.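

At this position, on a nitrogen on an aromatic ring, the shown compounds now offer their first direct step: 4-((ethoxycarbonyl)methyl)-1,3-thiazol-2-yl in place of 5-methyl-1,2-oxazol-3-yl gives a 1.6-fold higher number from compound 2 to compound 3 (0.21 log units; within the scatter) in this assay. The entering group has 11 heavy atoms against 6 and 4 hydrogen-bond acceptors against 2, yet this single change does not move the number beyond the scatter of repeated measurements. No measurement shown accounts for this result or links it to any property of either group.

On these data alone, this step changes the ring and its side chain together, so the contribution of each stays unknown. A plain 1,3-thiazol-2-yl group, or a carboxylic acid in place of the ethyl ester, would help to separate the two.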